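Swapping a Sulfonyl Methyl for 4-Methoxyphenyl

The source may hold more compounds than are shown below. What is called first, only, known or untested is meant among the compounds shown, and "the series" means these compounds.

Compound 1 `CS(=O)(=O)N1CCC2(CC1)OOC1(CCCC1)OO2` and compound 2 `CS(=O)(=O)N1CCC2(CC1)OOC1(CCCCC1)OO2` both carry a methyl on a sulfonyl sulfur. In a functional assay on Huh-7 cells (Homo sapiens) for cytotoxicity, read by MTT assay, with a stated time of 72 h (a lower number here means that less compound is tolerated, a higher number that more compound is tolerated), compound 1 gives > 100 ug/mL as a limit of the assay, not a number. In this assay compound 2 gives > 100 ug/mL as a limit as well, not a number. Both values stand at the limit of > 100 ug/mL in this assay, at which 2 of the 2 values shown sit, and no number separates them, so compound 2 offers only a limit as a starting point.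

Compound 3 `COc1ccc(S(=O)(=O)N2CCC3(CC2)OOC2(CCCCC2)OO3)cc1` has 4-methoxyphenyl in place of methyl on a sulfonyl sulfur and otherwise matches compound 2. For the measured compounds named here, no measured pair shows what such a swap does. An estimated a number no higher from compound 2 to compound 3 (the limit leaves the size open) is expected, no larger than the scatter, with any movement pointing to lower numbers in this assay rather than higher. For compound 3 the expected value is 100 ug/mL with an estimated range of 45 ug/mL to 200 ug/mL. A limit rather than a number is a likely outcome for compound 3 as well.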

Compound 3, half-maximal cytotoxic concentration: > 100 ug/mL
Compound 3 gave a limit, no number; the forecaster's own chance of this, stated with the estimate: 60%; the middle value lies on the limit itself.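

Compound 2 and compound 3 both give a limit rather than a number in this assay, so no step can be read between them: the limit of > 100 ug/mL in this assay, at which 3 of the 3 values shown sit.

The compounds shown leave open how much of each compound the cells tolerate, and whether 4-methoxyphenyl in place of methyl on a sulfonyl sulfur changes that at all.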